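Working notes on the shared core: amide-side variation

The source may report more compounds than this note shows. Statements on the series, on what has been measured and on what is new or still open speak of the compounds shown alone.

Measured compounds:
compound 1 `COc1cc2ncnc(N3CCc4ccccc43)c2cc1NC(=O)C=C(C)C`: 6390 nM
compound 2 `COc1cc2ncnc(N3CCCc4ccccc43)c2cc1NC(=O)C=C(C)C`: 6870 nM
compound 3 `C/C=C/C(=O)Nc1cc2c(N3CCCc4ccccc43)ncnc2cc1O[C@@H]1CCOC1`: 5930 nM

The read-out throughout is a functional assay on MCF7 cells (Homo sapiens) for antiproliferative activity, read by MTT assay, with a stated time of 72 h; on this read-out lower numbers stand for stronger inhibition and higher numbers for weaker inhibition. In this assay compound 1 gives 6390 nM, the second highest of the three numbers. Its nearest neighbour is compound 2, which gives 6870 nM; the furthest is compound 3, which gives 5930 nM. Both differences lie within the scatter, so nothing separates the three compounds on these numbers, and no order can be read from them.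

Compound 4 `COc1cc2ncnc(N3CCc4ccccc43)c2cc1NC(=O)/C=C/CN1CCCC1` is not yet measured in this assay. It differs from compound 1 in one place: 3-(pyrrolidin-1-yl)prop-1-en-1-yl in place of 2-methylprop-1-en-1-yl on a carbonyl carbon. Among the measured compounds shown here, no pair of measured compounds differs by a change of this kind, so there is no measured step to lean on; the three measured compounds only show that the rest of the shared core, with the amide side varied among the three as it is, sits at a similar level in this assay.

For the step from compound 1 to compound 4, a move toward a lower number is expected, of moderate size, a 2.3-fold lower number from compound 1 to compound 4 (0.36 log units; beyond the scatter), though the data give no direct support for a step beyond the scatter. Compound 4 is accordingly estimated at 2800 nM, within a range of 700 nM to 11000 nM.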

Compound 4, half-maximal inhibitory concentration: 1510 nM
Compound 4: the middle estimate sits 1.9-fold (0.27 log units) above what was measured, and the stated range covers the measured number.
By their numbers in this assay, from the lowest: compound 4; then compounds 3, 1 and 2 (each within the scatter of the next).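

In this assay, the place on the carbonyl carbon bonded to the amide-type nitrogen is now shown to affect the read-out: 3-(pyrrolidin-1-yl)prop-1-en-1-yl in place of 2-methylprop-1-en-1-yl gives a 4.2-fold lower number from compound 1 to compound 4 (0.63 log units; beyond the scatter), while compounds 1, 2 and 3 gave no separation at all. The entering group adds a nitrogen and a five-membered non-aromatic ring with one hetero atom as well as more heavy atoms, so this single step carries several structural changes at once and rests on one pair of compounds. No measurement available here accounts for the size or direction of the step.

The compounds shown leave open which part of the entering group goes with the lower number, and a morpholine ring, a dimethylamino group or a plain cyclopentyl ring in place of the pyrrolidin-1-yl part would be needed to separate the nitrogen from the ring and the added bulk. Also open, on these data alone, is whether the same change carries over to the shared core of compound 2, which differs from compound 1 elsewhere.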